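Oxazole ethers: amine ring and hydroxyl variation, rat inhibition

The source may report more compounds than this note shows. Statements on the series, on what has been measured and on what is new or still open speak of the compounds shown alone.

Measured so far:
- compound 1, `CCN(CC)CCCOc1cc(OC)ccc1-c1cc(-c2ccccc2)no1`: 7.8%
- compound 2, `COc1ccc(-c2cc(-c3ccccc3)no2)c(OCCCN2CCCCC2)c1`: 14.7%
- compound 3, `COc1ccc(-c2cc(-c3ccccc3)no2)c(OCC(O)CN2CCCCC2)c1`: 15.8%

All three share one core and differ only in the chain on the aromatic oxygen. In a functional assay on the whole organism (blood, strain Sprague-Dawley albino) with Rattus norvegicus as the target, with stated times of 30 min and 5 h, at a dose of 100 mg/kg by the oral route (a higher number here means more inhibition at the dose given (going by the name of the read-out), a lower number less inhibition), compound 3 gives the highest of the three numbers, but both its neighbours lie within the scatter: a number 1.1 percentage points higher from compound 2 to compound 3 (within the scatter) and a number 8 percentage points higher from compound 1 to compound 3 (within the scatter). The three numbers can therefore only be called level.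

Compound 4, `COc1ccc(-c2cc(-c3ccccc3)no2)c(OCCCN2CCCC2)c1`, is the next step from compound 3: 2-(pyrrolidin-1-yl)ethyl in place of 1-hydroxy-2-(piperidin-1-yl)ethyl on a saturated chain carbon bound to an oxygen on an aromatic ring. Among the measured compounds shown here, two measured steps bear on this. The amine change is close to that of a number 6.9 percentage points higher from compound 1 to compound 2 (within the scatter), and the loss of the hydroxy runs against a number 1.1 percentage points higher from compound 2 to compound 3 (within the scatter), both within the scatter. On that basis no step beyond the scatter is expected, and the estimate for compound 4 means a number 2.8 percentage points lower from compound 3 to compound 4 (within the scatter). Compound 4 is thus expected to give about 13%, within 3% to 24%.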

Compound 4, a percentage reported as inhibition, in the whole organism at one dose (the size of the read-out at that dose, not a potency): 13.4%
Beside the measured number, compound 4's estimate is 0.4 percentage points below it; the range from low to high includes it.
By their numbers in this assay, from the lowest: compounds 1, 4, 2 and 3 (each within the scatter of the next).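

In this assay the exchange of amines on the three-carbon chain now covers a five-membered ring as well: a number 1.3 percentage points lower from compound 2 to compound 4 (within the scatter) and a number 5.6 percentage points higher from compound 1 to compound 4 (within the scatter) leave pyrrolidin-1-yl level with both piperidin-1-yl and diethylamino. The double change from 2-hydroxy-3-(piperidin-1-yl)propyl to 3-(pyrrolidin-1-yl)propyl, with a number 2.4 percentage points lower from compound 3 to compound 4 (within the scatter), also gives no separation, so neither ring size nor the hydroxy sets any of these four compounds apart at this single dose. No measurement on these compounds offers an explanation for these level numbers.

Still open, on these data alone, is whether a morpholine or an N-methylpiperazine in place of these amines would give a step beyond the scatter. Also open, as far as these compounds go, is whether a longer chain between the aromatic oxygen and the amine, or 2-hydroxy-3-(pyrrolidin-1-yl)propyl, would do so.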